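The source may report more compounds than this note shows. Statements on the series, on what has been measured and on what is new or still open speak of the compounds shown alone.

Compound 2 `Cc1ccc2[nH]c(C(=O)N[C@H]3CN(S(=O)(=O)c4ccccc4)C[C@@H]3C(=O)N[C@@H]3CCCNC3)cc2c1` is the parent for this step. Within the data shown here, in an ADME assay on cells (Hepatocyte, Rattus norvegicus) for metabolic stability (a lower number here means slower removal, a higher number faster removal of the compound), compound 2 gives 9 uL/min and that is the lowest of the two numbers measured so far. Among the measured compounds shown here, the only other measured member, compound 1 `Cc1ccc2[nH]c(C(=O)N[C@H]3CN(S(=O)(=O)c4ccccc4)C[C@@H]3C(=O)NC[C@H]3CCCN3C)cc2c1`, gives 21 uL/min in this assay; the one measured step, a 2.3-fold lower number from compound 1 to compound 2 (0.37 log units; beyond the scatter), exchanged the whole group on the amide-type nitrogen and so does not bear on a change of configuration alone. For the measured compounds named here, compound 3 `Cc1ccc2[nH]c(C(=O)N[C@H]3CN(S(=O)(=O)c4ccccc4)C[C@@H]3C(=O)N[C@H]3CCCNC3)cc2c1` is the unmeasured partner of compound 2. the two compounds have the same atoms and bonds and differ only in configuration as drawn: 1 of 3 stereo elements differ; a stereocentre at a saturated ring carbon is drawn R in compound 2 and S in compound 3 No step among the measured compounds concerns a change of configuration at a saturated ring carbon, so the series gives nothing to anchor a direction, and the expected step of no change at the digits printed from compound 2 to compound 3 (within the scatter) is none beyond the scatter. Compound 3 is estimated to give 9 uL/min in this assay, with a range from 4 uL/min to 20 uL/min.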

Compound 3, intrinsic clearance in a liver preparation (reported as CLH), per the amount of preparation that the assay uses: 7 uL/min
Beside the measured number, compound 3's estimate is 1.3-fold (0.11 log units) above it; low and high end bracket the measured number.
By their numbers in this assay, from the lowest: compounds 3 and 2 (each within the scatter of the next); then compound 1.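

In this assay, the configuration at the saturated ring carbon of the piperidin-3-yl group can now be read on its own, and a 1.3-fold lower number from compound 2 to compound 3 (0.11 log units; within the scatter) leaves the two drawn forms indistinguishable in this read-out. The step of a 3.0-fold lower number from compound 1 to compound 3 (0.48 log units; beyond the scatter) has the same direction as the step to the other drawn form, so the exchange of the group on the amide-type nitrogen reads alike for both forms. The comparison at this stereocentre is a clean one, and its reading rests on one point: the fact that compounds 2 and 3 differ only in the configuration as drawn

As far as these compounds go, the configuration of the other two stereo elements remains open, since neither is varied between compound 2 and compound 3. Also open, from the compounds shown here alone, is how an open-chain amine, such as an aminoethyl group, would read in place of the piperidin-3-yl group on the amide-type nitrogen.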